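Benzotriazole substituent series: clearance notes, compound 3 outlook

A few compounds are considered here, and "the series" means these few. Any claim that something is new, unique, unknown or untested is made for them only; others in the source may bear on it.

Measured so far:
compound 1 `Fc1cc(Cl)ccc1-c1ccc(Cn2nnc3ccccc32)cn1` — 0.8 mL/min/g
compound 2 `N#Cc1cccc2c1nnn2Cc1ccc(-c2ccc(Cl)cc2F)nc1` — 0.1 mL/min/g

In an ADME assay on microsomes from liver (Rattus norvegicus, strain Wistar) for metabolic stability, tested at 2.5 uM (on this read-out higher numbers stand for fast clearance and lower numbers for slow clearance), compound 2 gives 0.1 mL/min/g, the lowest of the two numbers; its nearest neighbour is compound 1, which in this assay gives 0.8 mL/min/g. Among the compounds with values here, the single measured step, an 8.0-fold lower number from compound 1 to compound 2 (0.90 log units; beyond the scatter), is a change of hydrogen to cyano at one aromatic carbon of the fused system and lies beyond the scatter.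

Compound 3 `Fc1cc(Cl)ccc1-c1ccc(Cn2nnc3c(C(F)(F)F)cccc32)cn1` is not yet measured. It differs from compound 2 in one place: trifluoromethyl in place of cyano on an aromatic carbon. Within the data shown here, the group that leaves is the cyano group whose introduction gave the step of an 8.0-fold lower number from compound 1 to compound 2 (0.90 log units; beyond the scatter); the group that enters, trifluoromethyl, has no precedent, so no measured step covers it directly. Compound 1, with hydrogen at the same carbon, sets the only other reference point.

The expected number for compound 3 in this assay is 0.3 mL/min/g, with a range of 0.1 mL/min/g to 0.9 mL/min/g. This means an expected step of a 3.0-fold higher number from compound 2 to compound 3 (0.48 log units; beyond the scatter), estimated to sit between the two measured compounds rather than to extend the series in either direction.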

Compound 3, intrinsic clearance in a liver preparation (reported as CLH), per the amount of preparation that the assay uses: 0.2 mL/min/g
Estimate against measurement, compound 3: 1.5-fold (0.18 log units) above; low and high end bracket the measured number.
By their numbers in this assay, from the lowest: compounds 2 and 3 (each within the scatter of the next); then compound 1.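

Working notes on the substituted carbon: in this assay the change of hydrogen to trifluoromethyl gives a 4.0-fold lower number from compound 1 to compound 3 (0.60 log units; beyond the scatter) and points the same way as the cyano step, an 8.0-fold lower number from compound 1 to compound 2 (0.90 log units; beyond the scatter) and so the lower number at this carbon is no longer tied to the nitrile alone. Exchanging the two groups gives a 2.0-fold higher number from compound 2 to compound 3 (0.30 log units; within the scatter) and so this read-out does not separate them, although cyano brings 2 heavy atoms, a triple bond and 1 hydrogen-bond acceptor, while trifluoromethyl brings 4 heavy atoms and 0 hydrogen-bond acceptors. No measurement in hand bears on why either group gives a lower number than hydrogen.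

Still open, going by these compounds, is whether this carbon accepts substituents of other kinds with the same outcome, for example an amine, a carboxylic acid or a methoxy group, or whether the shift depends on something cyano and trifluoromethyl happen to share. Also open, on these data alone, is whether either group would give a similar step on another aromatic carbon of the fused system, or on a core altered elsewhere.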